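The source may hold more compounds than are shown below. What is called first, only, known or untested is meant among the compounds shown, and "the series" means these compounds.

Compound 1 `CCCn1c(=O)[nH]c2nc(-c3ccc(S(=O)(=O)N4CCN(c5ccc(Cl)cc5F)CC4)cc3)[nH]c2c1=O` is tested in an assay on CHO cells for displacement of a labelled ligand from adenosine receptor A2b (Homo sapiens), read by scintillation counting, with a stated time of 75 min, in the presence of a further agent that is not named here (a higher number here means a weaker inhibitor, a lower number a stronger inhibitor), where compound 1 gives 1.91 nM. Among the three compounds measured, this is the highest number: compound 2 `CCCn1c(=O)[nH]c2nc(-c3ccc(S(=O)(=O)N4CCN(c5ccc(Br)cc5)CC4)cc3)[nH]c2c1=O` gives 0.0835 nM, and compound 3 `CCCn1c(=O)[nH]c2nc(-c3ccc(S(=O)(=O)N4CCN(c5ccc(C)cc5)CC4)cc3)[nH]c2c1=O` gives 0.706 nM. The step of a 23-fold lower number from compound 1 to compound 2 (1.36 log units; beyond the scatter) is large, while a 2.7-fold lower number from compound 1 to compound 3 (0.43 log units; beyond the scatter) is modest; between those two, an 8.5-fold higher number from compound 2 to compound 3 (0.93 log units; beyond the scatter) is also modest.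

Compound 4 `CCCn1c(=O)[nH]c2nc(-c3ccc(S(=O)(=O)N4CCN(Cc5ccc(Br)cc5)CC4)cc3)[nH]c2c1=O` is not yet measured. It differs from compound 1 in one place: 4-bromobenzyl in place of 4-chloro-2-fluorophenyl on an amine nitrogen in a ring. The change resembles the step from compound 1 to compound 2 in that a bromo group is carried on the ring, but here the ring is joined to the ring nitrogen through a one-carbon link, a change for which no measured pair is shown. The large step of a 23-fold lower number from compound 1 to compound 2 (1.36 log units; beyond the scatter) suggests the bromo-bearing ring is well tolerated, so a lower number than compound 1 is expected for compound 4, though with wide uncertainty because only a 23-fold lower number from compound 1 to compound 2 (1.36 log units; beyond the scatter) bears on it directly. The expected step is a 6.4-fold lower number from compound 1 to compound 4 (0.80 log units; beyond the scatter). In this assay compound 4 is estimated at 0.3 nM, within a range from 0.05 nM to 2 nM.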

Compound 4, inhibition constant: 0.153 nM
For compound 4 the middle estimate is 2.0-fold (0.29 log units) above the measured one; low and high end bracket the measured number.
By their numbers in this assay, from the lowest: compounds 2 and 4 (each within the scatter of the next); then compound 3; then compound 1.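

In this assay, adding a one-carbon link between the bromo-bearing ring and the ring nitrogen leaves compound 4 indistinguishable from compound 2 (a 1.8-fold higher number from compound 2 to compound 4 (0.26 log units; within the scatter)), so this position tolerates the ring being joined through that link as well as directly. The 4-bromobenzyl group also gives a clearly lower number than either the 4-chloro-2-fluorophenyl group (a 12-fold lower number from compound 1 to compound 4 (1.10 log units; beyond the scatter)) or the 4-methylphenyl group (a 4.6-fold lower number from compound 3 to compound 4 (0.66 log units; beyond the scatter)). Nothing available here explains these differences. The compounds shown leave open whether a longer chain in place of the one-carbon link would give a similar number. They also leave open whether the bromo group matters once the link is present, as a benzyl group with no bromo, or with an amine or a carboxylic acid in its place, would show.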